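The source may hold more compounds than are shown below. What is called first, only, known or untested is meant among the compounds shown, and "the series" means these compounds.

Compound 1 `C=CC1=C(C(=O)Nc2cccc(C)c2)C(c2ccc(F)cc2)OC1`, compound 2 `C=CC1=C(C(=O)NCc2ccc(C)cc2)C(c2ccc(F)cc2)OC1` and compound 3 `C=CC1=C(C(=O)Nc2ccc(OCC)cc2)C(c2ccc(F)cc2)OC1` share one core and differ only in the group attached to the amide nitrogen. In a functional assay on HeLa cells (Homo sapiens) for cytotoxicity, read by MTT assay, with a stated time of 24 h (a lower number here means a stronger inhibitor, a higher number a weaker inhibitor), compound 1 gives "not active" (no number reported), with no number reported. In this assay compound 2 reaches only the limit of the assay, > 100000 nM, which is not a measured number. Compound 3 likewise stands at a limit in this assay, > 100000 nM, so no number is known for it and nothing separates it from the other two. Compound 4 `C=CC1=C(C(=O)Nc2ccccc2)C(c2ccc(F)cc2)OC1` has not yet been measured; it differs from compound 3 by hydrogen in place of ethoxy on an aromatic carbon. Within the data shown here, no step between two measured compounds is available, so the size of this change cannot be read from any measured pair. Because the limit of > 100000 nM in this assay, at which 2 of the 3 values shown sit, is all the measured compounds show, compound 4 is expected to sit at that limit as well, with a step that the limit leaves unreadable from compound 3 to compound 4 that amounts to none beyond the scatter. Compound 4 is therefore estimated at 150000 nM, within a range from 50000 nM to 500000 nM.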

Compound 4, half-maximal inhibitory concentration: > 100000 nM
Compound 4 was reported as a limit; the forecaster's own chance of this, stated with the estimate: 85%; the middle value is on the limit's open side.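

The steps from compound 2 and compound 3 to compound 4 cannot be read, since each of these values is a limit and not a measured number. Which group on the amide nitrogen, if any, would give a measured number in this assay stays open, with the compounds showing only this: the limit of > 100000 nM in this assay, at which 3 of the 4 values shown sit.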